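The source may hold more compounds than are shown below. What is called first, only, known or untested is meant among the compounds shown, and "the series" means these compounds.

Among the measured compounds shown here, in an ADME assay on NIH3T3 cells (Mus musculus) for cytotoxicity, read by WST assay, with a stated time of 72 h (a higher number here means that more compound is tolerated, a lower number that less compound is tolerated), compound 1 `CCCCCCCC/C=C\c1c(C)c(/C=C\CCCCCCCC)c2[n+](c1C)CCC2` gives 23.5 uM, the higher of the two numbers so far, and compound 2 `CCCCCCCC/C=C/c1c(C)c(/C=C/CCCCCCCC)c2[n+](c1C)CCC2` gives 4.4 uM. For the measured compounds named here, the only measured step is a 5.3-fold lower number from compound 1 to compound 2 (0.73 log units; beyond the scatter), and it rests on (the fact that compounds 1 and 2 differ only in the configuration as drawn). Compound 3 `CCCCCCCC/C=C\c1c(C)cc(C)[n+]2c1CCC2` makes a different kind of change from compound 1: hydrogen in place of dec-1-en-1-yl on an aromatic carbon. In words, hydrogen stands in place of dec-1-en-1-yl on an aromatic carbon. Going by the values given here, no measured step removes a chain, so the step from compound 1 to compound 2 serves only as a yardstick for size and gives no direction. A step of comparable size is expected in this assay, tentatively towards a higher number, though this direction is a judgement and is not shown by the data. The expected change is a 3.4-fold higher number from compound 1 to compound 3 (0.53 log units; beyond the scatter). Compound 3 is estimated at 80 uM, with an expected range of 20 uM to 250 uM.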

Compound 3, half-maximal toxic concentration: 6.9 uM
Beside the measured number, compound 3's estimate is 12-fold (1.06 log units) above it; measured number outside the range, below it.
By their numbers in this assay, from the lowest: compounds 2 and 3 (each within the scatter of the next); then compound 1.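

In this assay, taking the dec-1-en-1-yl group off the aromatic carbon two atoms from the ring nitrogen gives a 3.4-fold lower number from compound 1 to compound 3 (0.53 log units; beyond the scatter), so this position is not silent in this assay. In this one pair, the presence of the second chain goes with more compound being tolerated, and its loss does not raise the number. Nothing at hand gives a cause for this step.

Still open, going by these compounds, is how the number at this position depends on chain length: a methyl, a shorter chain or a longer chain could each place the number nearer to compound 3 or to compound 1. Also open, on these data alone, is whether an amine or a carboxylic acid at this position would give a different number, and whether the same step holds for a chain drawn E.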